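This account rests on a few compounds, and the source may have more. Where it says the series, first, only, none or still open, it means among the compounds named here.

Within the data shown here, compound 1 `CCC1=C(O)c2c(oc(-c3cccc(C)c3)cc2=O)C(CC)(CC)C1=O` is the one compound here that gives an actual number in a functional assay on KB cells (Homo sapiens) for antiproliferative activity, read by sulforhodamine B assay, with a stated time of 3 days; a higher number here means that more compound is needed for the effect, a lower number that less compound is needed: in this assay compound 1 gives 49.7 uM. Compound 2 `CCC1=C(O)c2c(oc(-c3cccc(OC(F)(F)F)c3)cc2=O)C(CC)(CC)C1=O` carries a trifluoromethoxy group in place of the methyl group on an aromatic carbon. In this assay compound 2 reaches only a limit of the assay, > 47.4 uM. The step that the limit leaves unreadable from compound 1 to compound 2 therefore cannot be sized because the limit of > 47.4 uM in this assay, at which 1 of the 2 values shown sits, is all that is reported for it.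

Compound 3 `CCC1=C(O)c2c(oc(-c3ccc(OC)c(Cl)c3)cc2=O)C(CC)(CC)C1=O` differs from compound 1 by 3-chloro-4-methoxyphenyl in place of 3-methylphenyl on an aromatic carbon. Among the measured compounds shown here, the only measured step, a step that the limit leaves unreadable from compound 1 to compound 2, bears on this change in a loose way, as both exchange the 3-methylphenyl group, yet it gives no readable size. With a single number and one limit, there is no basis for expecting a step beyond the scatter in either direction. Compound 3 is therefore expected to give an estimated 50 uM in this assay, with a range from 15 uM to 120 uM. The expected step of a 1.0-fold higher number from compound 1 to compound 3 (0.00 log units; within the scatter) is accordingly estimated to be small, and a result reported only as a limit is quite possible.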

Compound 3, concentration for half-maximal effect: 24.9 uM
For compound 3 the middle estimate is 2.0-fold (0.30 log units) above the measured one, within the range that was stated.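

In this assay, putting 3-chloro-4-methoxyphenyl in place of 3-methylphenyl, on the aromatic carbon next to the ring oxygen, gives a 2.0-fold lower number from compound 1 to compound 3 (0.30 log units; within the scatter). Among these compounds, this is the first readable step at this position: a group of 9 heavy atoms, with a chlorine and a hydrogen-bond acceptor, replaces one of 7 heavy atoms, and the number stays within the scatter of that of compound 1. The earlier exchange still offers no size for comparison, and the step to compound 2 cannot be read, as the value of compound 2 is only a limit of the assay: the limit of > 47.4 uM in this assay, at which 1 of the 3 values shown sits.

The chlorine and the methoxy group enter together in compound 3, so the compounds shown do not tell what either one does alone, or whether moving either one elsewhere on the aromatic ring would matter. Also open, going by these compounds, is how an amine or a carboxylic acid on that ring would read in this assay, and whether any exchange at this position gives a step beyond the scatter.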